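Chloro for fluoro on the benzamide of compound 3

The source may hold more compounds than are shown below. What is called first, only, known or untested is meant among the compounds shown, and "the series" means these compounds.

The three measured compounds share one core, an anilide bearing a chloro group and a fused bicyclic heteroaromatic ring, and differ in the acyl part. Compound 1 `COc1cc(C(=O)Nc2ccc(Cl)c(-c3nc4ccccc4[nH]3)c2)cc(OC)c1OC` carries a trimethoxybenzoyl group and, in a functional assay on Shh Light II cells for inhibition of Sonic hedgehog protein (Mus musculus), read by reporter gene assay, with a stated time of 48 h, in the presence of a further agent that is not named here (on this read-out higher numbers stand for weaker inhibition and lower numbers for stronger inhibition), compound 1 gives 79.8 nM. Compound 2 `CCOc1cc(C(=O)Nc2ccc(Cl)c(-c3nc4ccccc4s3)c2)cc(OCC)c1OCC`, with a triethoxybenzoyl group and a different fused ring, is reported in this assay as "not active" (no number reported). Compound 3 `O=C(Nc1ccc(Cl)c(-c2nc3ccccc3[nH]2)c1)c1ccc(F)cc1`, with a 4-fluorobenzoyl group, gives 251 nM in this assay. Among the two numbers in hand, compound 3 stands highest, and its gap to compound 1 lies beyond the scatter.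

The step to compound 4 `O=C(Nc1ccc(Cl)c(-c2nc3ccccc3[nH]2)c1)c1ccc(Cl)cc1` is chloro in place of fluoro on an aromatic carbon. Going by the values given here, no pair of measured compounds shows such a halogen exchange, so the data give no guide to its size. The author expects a change no larger than the scatter, a 1.4-fold lower number from compound 3 to compound 4 (0.14 log units; within the scatter), and for compound 4 estimates 180 nM in this assay, within a range from 70 nM to 500 nM.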

Compound 4, half-maximal inhibitory concentration: 224 nM
Compound 4: middle estimate off by 1.2-fold (0.09 log units), on the low side; measured number inside the range.
By their numbers in this assay, from the lowest: compound 1; then compounds 4 and 3 (each within the scatter of the next).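

At this aromatic carbon, para to a large group, the change from 4-fluorophenyl to 4-chlorophenyl gives a 1.1-fold lower number from compound 3 to compound 4 (0.05 log units; within the scatter) in this assay, so this read-out does not separate the two halogens. This is the first halogen exchange among the compounds shown, and it indicates that, on the shared core, this position accepts either fluoro or chloro with no change beyond the scatter. Nothing available here explains why the two compounds read alike.

Still open, from the compounds shown here alone, is how a group of another kind at this carbon, such as an amine, a carboxylic acid or a nitrile, would read in this assay. Equally open, going by these compounds, is whether a plain phenyl, with hydrogen in place of the halogen, would read like compound 3 and compound 4.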